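A few compounds are considered here, and "the series" means these few. Any claim that something is new, unique, unknown or untested is made for them only; others in the source may bear on it.

In a functional assay on SK-BR-3 cells (Homo sapiens) for inhibition, read by MTT assay, with a stated time of 2 days, tested at 100 uM (a higher number here means more inhibition of growth at the concentration tested, a lower number less inhibition of growth), the three measured compounds gave:
- compound 1 `CNC(=O)c1cc(Oc2ccc3nc(NC(=O)Nc4cc(C(F)(F)F)cc(C(F)(F)F)c4)sc3c2)ccn1`: 96.3%
- compound 2 `CNC(=O)c1cc(Oc2ccc3nc(NC(=O)c4ccc(Cl)cc4)sc3c2)ccn1`: 83%
- compound 3 `CNC(=O)c1cc(Oc2ccc3nc(NC(=O)Nc4ccc(Cl)cc4)sc3c2)ccn1`: 77.4%

Compound 2 stands second highest of these three numbers. Its nearest neighbour is compound 3, with the step of a number 5.6 percentage points lower from compound 2 to compound 3 (within the scatter); compound 1 lies further off, its number higher beyond the scatter.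

Compound 4 `CNC(=O)c1cc(Oc2ccc3nc(NC(=O)Nc4ccc(Cl)cc4Cl)sc3c2)ccn1` differs from compound 2 by (2,4-dichlorophenyl)amino in place of 4-chlorophenyl on a carbonyl carbon. Going by the values given here, the one measured step that bears on this, a number 5.6 percentage points lower from compound 2 to compound 3 (within the scatter), makes the same swap of a carbon-linked ring for a nitrogen-linked one and stayed within the scatter. Among the compounds with values here, the added second chlorine has no measured counterpart. In this assay compound 4 is therefore expected to give 79%, within 64% to 92%. The expected step of a number 4 percentage points lower from compound 2 to compound 4 (within the scatter) is estimated to stay within the scatter.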

Compound 4, percent growth inhibition at one concentration: 91.7%
Beside the measured number, compound 4's estimate is 12.7 percentage points below it; measured number inside the range.
By their numbers in this assay, from the lowest: compounds 3, 2, 4 and 1 (each within the scatter of the next, the first and the last beyond it).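

The added chlorine is what this result brings out: in this assay chloro in place of hydrogen on an aromatic carbon gives a number 14.3 percentage points higher from compound 3 to compound 4 (beyond the scatter) and so moves the number past the scatter. Set against the 4-chlorophenyl group on the carbonyl carbon, (2,4-dichlorophenyl)amino gives a number 8.7 percentage points higher from compound 2 to compound 4 (within the scatter) and cannot be told apart from it. Only this one added chlorine has been read as a single change on the ring, so its effect rests on a single pair.

As far as these compounds go, whether a methyl or methoxy group in the same place would match chloro remains open. No measured evidence bears on why the added chlorine raises the number.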